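The source may report more compounds than this note shows. Statements on the series, on what has been measured and on what is new or still open speak of the compounds shown alone.

Measured so far in a functional assay on K562 cells (Homo sapiens) for antiproliferative activity, read by MTT assay, with a stated time of 48 h; a higher number here means a weaker inhibitor, a lower number a stronger inhibitor:
compound 1, `COc1ccc(-c2ccc3c(c2)C(=O)C(=O)N3Cc2ccc3ccccc3c2)cc1`, where compound 1 gives 400 nM
compound 2, `COc1ccc(CN2C(=O)C(=O)c3c(-c4ccc(OC)cc4)cccc32)cc1`, where compound 2 reaches only the limit of > 10000 nM
compound 3, `COc1ccc(CN2C(=O)C(=O)c3cc(-c4ccc(OC)c(OC)c4)ccc32)cc1`, where compound 3 gives 260 nM

Three compounds share one core and differ in the aryl group attached to it and in where that group sits. Compound 3 and compound 1 give numbers that lie within the usual scatter of each other, so neither can be called stronger than the other. For compound 2 only a limit is known: the limit of > 10000 nM in this assay, at which 1 of the 3 values shown sits.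

The next compound, compound 4, `COc1ccc(CN2C(=O)C(=O)c3cc(-c4ccncc4)ccc32)cc1`, keeps everything of compound 3 except one group: pyridin-4-yl in place of 3,4-dimethoxyphenyl on an aromatic carbon. Within the data shown here, no measured pair in this set differs in only one place, so no measured step guides the size of this change. A step beyond the scatter toward a weaker inhibitor is expected, since the group that enters is smaller and carries fewer acceptors than the group that leaves. Compound 4 is therefore expected to give about 1500 nM, estimated to fall between 400 nM and 8000 nM. That estimate means an expected step of a 5.8-fold higher number from compound 3 to compound 4 (0.76 log units; beyond the scatter).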

Compound 4, half-maximal inhibitory concentration: 40 nM
Estimate against measurement, compound 4: 38-fold (1.57 log units) above; the measured number lies below the stated range.
By their numbers in this assay, from the lowest: compound 4; then compounds 3 and 1 (each within the scatter of the next). At a limit, above all of these: compound 2.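

In this assay, among these compounds, pyridin-4-yl in place of 3,4-dimethoxyphenyl gives a 6.5-fold lower number from compound 3 to compound 4 (0.81 log units; beyond the scatter), and this is the first comparison in the set that differs in only one place. It shows that this aromatic carbon does not need the larger 3,4-dimethoxyphenyl group, and that a smaller aromatic ring holding a nitrogen gives a stronger inhibitor here. Nothing shown explains why the step runs in this direction.

The compounds shown leave open whether the ring nitrogen matters in itself or whether losing the methoxy groups accounts for the step, and an unsubstituted phenyl at this carbon would separate the two. Going by these compounds, it also remains open how pyridin-3-yl, or an aryl ring carrying an amine or a carboxylic acid, would behave at this same place.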